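A Fluoro for a Methylsulfanyl: Predicting Compound 4

A few compounds are considered here, and "the series" means these few. Any claim that something is new, unique, unknown or untested is made for them only; others in the source may bear on it.

Compound 1, `COc1ccc(/C=C/C=C/C(=O)N2CCCCC2)c(OC)c1OC`: in an assay for inhibition of Polyunsaturated fatty acid 5-lipoxygenase (Homo sapiens), read by spectrophotometry, tested at 20 uM (a lower number here means less inhibition, a higher number more inhibition at the concentration tested (going by the name of the read-out)), compound 1 gives 36%.
Compound 2, `O=C(/C=C/c1ccc(O)c(O)c1)N1CCCCC1`: in this assay compound 2 gives 55.2%.
Compound 3, `CSc1ccc(/C=C/C=C/C(=O)N2CCCCC2)cc1`: in this assay compound 3 gives 11.8%.

Among these three, compound 3 gives the lowest number. The nearest is compound 1, whose number is higher by more than the usual scatter, and the furthest is compound 2, higher again by well more than the scatter. Compound 4, `O=C(/C=C/C=C/c1ccc(F)cc1)N1CCCCC1`, has not yet been measured. It differs from compound 3 in one place: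

fluoro in place of methylsulfanyl on an aromatic carbon

Among the measured compounds shown here, no measured pair shows this swap, so there is no direct guide to its direction or size. The three numbers that are known do not point to a strong effect of a small group at this position, so in this assay only a step within the scatter is expected, with the step from compound 3 to compound 4 estimated as a number 3.2 percentage points higher from compound 3 to compound 4 (within the scatter). Compound 4 is therefore expected to give about 15%, with a range from 2% to 35%.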

Compound 4, a percentage reported as inhibition, at one concentration (the size of the read-out at that concentration, not a potency): 48.7%
Beside the measured number, compound 4's estimate is 33.7 percentage points below it, outside the stated range (above it).
By their numbers in this assay, from the lowest: compound 3; then compound 1; then compounds 4 and 2 (each within the scatter of the next).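

In this assay, placing fluoro in place of methylsulfanyl gives a number 36.9 percentage points higher from compound 3 to compound 4 (beyond the scatter), so the group on this aromatic carbon, para to a large group, has a strong bearing on the read-out. The change is small when counted in atoms: a carbon and a sulfur leave, and a single fluorine enters. Nothing measured here accounts for the size of this step.

Among the compounds shown here, the two compounds cannot separate a gain from fluoro itself from a loss caused by methylsulfanyl, as they offer only one comparison at this position. A chloro group, a nitrile or an amine on this same carbon, with the rest of compound 4 unchanged, would show whether the higher number is particular to fluoro or is shared by other replacements for methylsulfanyl.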